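The source may hold more compounds than are shown below. What is called first, only, known or untested is meant among the compounds shown, and "the series" means these compounds.

Measured compounds:
Compound 1: `CC(C)c1ccccc1OCC(O)CN1CCC(NS(=O)(=O)c2ccc(F)cc2)CC1` with 104 nM
Compound 2: `O=S(=O)(NC1CCN(CC(O)COc2ccccc2-c2ccccc2)CC1)c1cccc(Cl)c1` with 33 nM

Both compounds were tested in an assay on HEK293 cells for displacement of a labelled ligand from 5-hydroxytryptamine receptor 7 (Homo sapiens), read by scintillation counting, with a stated time of 1 h; a higher number here means a weaker inhibitor, a lower number a stronger inhibitor. Of the two, compound 2 gives the lower number, and the gap between compound 2 and compound 1 lies beyond the scatter of repeated measurements, so compound 2 stands as the stronger inhibitor of this pair. For the measured compounds named here, compound 1 and compound 2 differ in more than one place, so no single structural step between them can be read out.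

Compound 3 is `O=S(=O)(NC1CCN(CC(O)COc2ccccc2-c2ccccc2)CC1)c1ccc(F)cc1` and has not yet been measured. It keeps the core of compound 2 and differs from it in one place only: 4-fluorophenyl in place of 3-chlorophenyl on a sulfonyl sulfur. Going by the values given here, there is no measured pair in this set that isolates this exchange, so the size of its effect cannot be read from the data. Without such a reference, the expectation for compound 3 rests on the value of compound 2, with a modest allowance for change in either direction. Compound 3 is expected to give about 60 nM in this assay, within a range of 20 nM to 180 nM. The step this implies, a 1.8-fold higher number from compound 2 to compound 3 (0.26 log units; within the scatter), is expected to stay within the usual scatter.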

Compound 3, inhibition constant: 59 nM
Compound 3: middle estimate off by 1.0-fold (0.01 log units), on the high side; the measured number falls inside the stated range.
By their numbers in this assay, from the lowest: compounds 2, 3 and 1 (each within the scatter of the next, the first and the last beyond it).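

In this assay, putting 4-fluorophenyl in place of 3-chlorophenyl on a sulfonyl sulfur gives a 1.8-fold higher number from compound 2 to compound 3 (0.25 log units; within the scatter) and so shows that this exchange, which moves the halogen and changes it in a single step, cannot be told apart from repeat-measurement noise at this position. Compound 3 also supplies a second one-place comparison, phenyl in place of isopropyl on an aromatic carbon, which gives a 1.8-fold lower number from compound 1 to compound 3 (0.25 log units; within the scatter) and is likewise unresolved, so neither exchange taken alone shows a real effect on the number. No other measurement accompanies these values that could explain them.

On these data alone, since the halogen and its place on the ring change together here, a 4-chlorophenyl or 3-fluorophenyl group on the sulfonyl sulfur would be needed to separate the two, and a group of a different kind there, such as a methyl or a pyridine ring, remains open as well. As far as these compounds go, on the aromatic carbon, it also remains open how the number would respond to a smaller group such as methoxy or to an amine.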